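Removing a Methoxy Group from an Indole Growth Inhibitor

The source may hold more compounds than are shown below. What is called first, only, known or untested is meant among the compounds shown, and "the series" means these compounds.

Compound 2 `COc1ccc(-c2[nH]c3ccc(OC)cc3c2/C=C(\C#N)S(=O)(=O)c2ccccc2)cc1` gives 563 nM in a functional assay on U-251 cells (Homo sapiens) for inhibition, read by sulforhodamine B assay, with a stated time of 48 h; on this read-out lower numbers stand for stronger inhibition of growth and higher numbers for weaker inhibition of growth. Among the measured compounds shown here, its only measured neighbour, compound 1 `COc1ccc(-c2[nH]c3ccccc3c2/C=C(\C#N)S(=O)(=O)c2ccccc2)cc1`, gives 473 nM, and the two numbers lie within the scatter of each other, so neither can be called the more active. For the measured compounds named here, the one step measured so far, a 1.2-fold higher number from compound 1 to compound 2 (0.08 log units; within the scatter), is the addition of a methoxy group to the shared core and stays within the scatter.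

Compound 3 `COc1ccc2[nH]c(-c3ccccc3)c(/C=C(\C#N)S(=O)(=O)c3ccccc3)c2c1` differs from compound 2 by hydrogen in place of methoxy on an aromatic carbon. Going by the values given here, no measured step covers this change: the only step available concerns a methoxy group at a different place and did not move the number beyond the scatter. With nothing pointing in either direction, the expected step is a 1.0-fold lower number from compound 2 to compound 3 (0.00 log units; within the scatter), none beyond the scatter. Compound 3 is therefore estimated to give about 560 nM in this assay, with a range from 250 nM to 1300 nM.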

Compound 3, concentration for 50% growth inhibition: 4600 nM
Estimate against measurement, compound 3: 8.2-fold (0.91 log units) below; the measured number lies above the stated range.
By their numbers in this assay, from the lowest: compounds 1 and 2 (each within the scatter of the next); then compound 3.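

Here the methoxy group carries real weight. In this assay, going from 4-methoxyphenyl to phenyl gives an 8.2-fold higher number from compound 2 to compound 3 (0.91 log units; beyond the scatter) and so weaker inhibition of growth, whereas the methoxy step at the other place on the shared core, a 1.2-fold higher number from compound 1 to compound 2 (0.08 log units; within the scatter), stayed within the scatter. A methoxy group's contribution therefore depends on where it sits in this series, at least across these two steps, and the one on the 4-methoxyphenyl ring is the one that counts. Nothing available here gives a reason for this difference.

On these data alone, it remains open whether the methoxy group itself is needed at this place or whether another group, such as a hydroxyl, an ethoxy or a chlorine, would serve equally well. As far as these compounds go, it is also open whether removing this methoxy group would cost as much in a compound without the second methoxy group.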